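Lengthening the Hydroxyalkyl Chain on the Amide Nitrogen

This account rests on a few compounds, and the source may have more. Where it says the series, first, only, none or still open, it means among the compounds named here.

Of the compounds shown here, three sharing one core have been measured in an assay on HEK293 cells for displacement of a labelled ligand from adenosine receptor A2b (Homo sapiens), read by scintillation counting, with a stated time of 30 min, tested at 10 uM; a lower number here means less inhibition, a higher number more inhibition at the concentration tested (going by the name of the read-out). Compound 1 `COc1cccc2cc(C(=O)N[C@@H](CO)C(=O)O)c(=O)oc12` gives 24%. Compound 2 `COc1cccc2cc(C(=O)NC3CCCC3)c(=N)oc12` gives 47%. Compound 3 `CCC(CO)NC(=O)c1cc2cccc(OC)c2oc1=N` gives 39%. Compound 3 therefore stands clearly above compound 1, a gap beyond the usual scatter, while compound 3 and compound 2 lie within the scatter of each other, so no order between those two can be read from the numbers. Among the measured compounds shown here, the one step that changes a single place is a number 8 percentage points lower from compound 2 to compound 3 (within the scatter), a swap of the group on the amide-type nitrogen.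

Compound 4 `COc1cccc2cc(C(=O)NCCCCCO)c(=N)oc12` is the next member. It differs from compound 3 by 5-hydroxypentyl in place of 1-(hydroxymethyl)propyl on an amide-type nitrogen. For the measured compounds named here, the only measured step bearing on this is the one from compound 2 to compound 3, which also exchanged the group on that nitrogen and stayed within the scatter. Going by the values given here, nothing among the measured compounds points to a shift beyond the scatter for this change.

Compound 4 is therefore expected to give 38%, with a range from 22% to 54%. That estimate means an expected step of a number 1 percentage points lower from compound 3 to compound 4 (within the scatter), which is expected to remain within the scatter.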

Compound 4, a percentage reported as inhibition, at one concentration (the size of the read-out at that concentration, not a potency): > 70%
Compound 4 gave a limit, no number (the forecaster's own chance of this, stated with the estimate: 0%); middle value at least 32 percentage points away from the limit.
By their numbers in this assay, from the lowest: compound 1; then compounds 3 and 2 (each within the scatter of the next). At a limit, above all of these: compound 4.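

In this assay, among the compounds shown here, the group on the amide-type nitrogen matters much more than the earlier compounds suggested: 5-hydroxypentyl in place of 1-(hydroxymethyl)propyl gives a number at least 31 percentage points higher from compound 3 to compound 4 (beyond the scatter), and 5-hydroxypentyl in place of cyclopentyl gives a number at least 23 percentage points higher from compound 2 to compound 4 (beyond the scatter). The first of these swaps leaves the counts of hydrogen-bond donors and acceptors unchanged, and neither group has a ring or a net charge, so a large step can occur here with all of those held the same. The result for compound 4 is a limit of the assay and not a number, which means that both steps give only a minimum size: the limit of > 70% in this assay, at which 1 of the 4 values shown sits.

Compound 3 and compound 4 differ at once in the length of the chain and in its branching, and the compounds shown do not separate these two features. Also open, going by these compounds, is how a longer chain would read in this assay, or an amine or a carboxylic acid in place of the hydroxyl of the 5-hydroxypentyl group.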